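Trimming the propargyl ether on a piperidinyl sulfonamide

The source may hold more compounds than are shown below. What is called first, only, known or untested is meant among the compounds shown, and "the series" means these compounds.

Compound 1 `Cc1cc(C)c(S(=O)(=O)N2CCC(N3CCC(CCO)CC3)CC2)c(C)c1` gives 19 nM in a functional assay on DLD-1 cells (Homo sapiens) for antiproliferative activity, read by CellTiter-Glo, with a stated time of 72 h; on this read-out lower numbers stand for stronger inhibition and higher numbers for weaker inhibition.
Compound 2 `CC1CCN(C2CCN(S(=O)(=O)c3ccccc3-c3ccccc3)CC2)CC1` gives 0.96 nM in this assay.
Compound 3 `C#CCOCCC1CCCCN1C1CCN(S(=O)(=O)c2ccccc2)CC1` gives > 5000 nM in this assay, which is a limit of the assay and not a number.

Compound 3 thus stands at the limit of this assay (the limit of > 5000 nM in this assay, at which 1 of the 3 values shown sits), so its potency is bounded on one side only. Going by the values given here, no measured step links compound 3 to compound 1 or compound 2, and no pair of measured compounds differs in a single place, so nothing about the size of any one change can be read from the numbers.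

Compound 4 `C#CCC1CCCCN1C1CCN(S(=O)(=O)c2ccccc2)CC1` differs from compound 3 in one place: ethynyl in place of (propargyloxy)methyl on a saturated chain carbon bound to a saturated ring carbon. Because the value of compound 3 in this assay is only a limit (> 5000 nM), the step to compound 4 cannot be sized from the data, and the expectation is that compound 4 stays weak, with at most a modest gain that may still leave it at the limit. Compound 4 is therefore estimated at 4000 nM in this assay, expected to lie between 800 nM and 20000 nM. The expected step is an at least 1.2-fold lower number from compound 3 to compound 4 (0.09 log units; that floor lies within the scatter).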

Compound 4, half-maximal inhibitory concentration: > 5000 nM
Compound 4: no number, only a limit; the forecaster's own chance of this, stated with the estimate: 55%; at least 1.2-fold (0.09 log units) between middle value and limit.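

Going by these compounds alone, compound 3 and compound 4 both stand at a limit of the assay and not at a number, so no step between them can be read: the limit of > 5000 nM in this assay, at which 2 of the 4 values shown sit.
The compounds shown leave open how far each lies past that limit, and whether ethynyl in place of (propargyloxy)methyl changes anything in this assay at all.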